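A few compounds are considered here, and "the series" means these few. Any claim that something is new, unique, unknown or untested is made for them only; others in the source may bear on it.

The compounds here share one core, seen in compound 1 `Cc1nn(C)c(Oc2ccccc2F)c1/C=N\CCCCCCOc1cc2oc(=O)cc(C)c2cc1Cl`, and differ only in the ring that hangs from the oxygen. In a functional assay on HepG2 cells (Homo sapiens) for antiproliferative activity, read by MTT assay, with a stated time of 72 h (on this read-out lower numbers stand for stronger inhibition and higher numbers for weaker inhibition), compound 1 gives only a limit of the assay, > 25000 nM, so its true strength is not known. Compound 2 `Cc1nn(C)c(Oc2cccc(Cl)c2)c1/C=N\CCCCCCOc1cc2oc(=O)cc(C)c2cc1Cl`, which carries a 3-chlorophenyl in place of the 2-fluorophenyl, gives 6220 nM in this assay. Compound 3 `Cc1nn(C)c(Oc2ccc(Br)cc2)c1/C=N\CCCCCCOc1cc2oc(=O)cc(C)c2cc1Cl`, with a 4-bromophenyl, gives 4630 nM. The two changes away from compound 1 are thus an at least 4.0-fold lower number from compound 1 to compound 2 (0.60 log units; beyond the scatter) and an at least 5.3-fold lower number from compound 1 to compound 3 (0.73 log units; beyond the scatter), while between the two halogenated rings there is only a 1.3-fold lower number from compound 2 to compound 3 (0.13 log units; within the scatter). Both measured steps rest on the limit (the limit of > 25000 nM in this assay, at which 1 of the 3 values shown sits), so their size is a floor, not a fixed figure.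

Compound 4 `Cc1ccccc1Oc1c(/C=N\CCCCCCOc2cc3oc(=O)cc(C)c3cc2Cl)c(C)nn1C` differs from compound 1 by methyl in place of fluoro on an aromatic carbon, so the group stays on the carbon ortho to a large group, where fluoro gave no measurable effect. Neither measured step tests this position, so the expected step is an at least 1.6-fold lower number from compound 1 to compound 4 (0.22 log units; that floor lies within the scatter), with wide uncertainty. Compound 4 is therefore estimated at 15000 nM, between 5000 nM and 40000 nM.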

Compound 4, half-maximal inhibitory concentration: 7830 nM
Compound 4: middle estimate off by 1.9-fold (0.28 log units), on the high side, within the range that was stated.
By their numbers in this assay, from the lowest: compounds 3, 2 and 4 (each within the scatter of the next). At a limit, above all of these: compound 1.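

Compound 4 shows that a group on this carbon, ortho to a large group, does not in itself keep the number at the limit, since methyl in place of fluoro gives an at least 3.1-fold lower number from compound 1 to compound 4 (0.50 log units; beyond the scatter). In this assay, the 2-methylphenyl ring of compound 4 cannot be told apart from the two halogenated rings, with a 1.7-fold higher number from compound 3 to compound 4 (0.23 log units; within the scatter) and a 1.3-fold higher number from compound 2 to compound 4 (0.10 log units; within the scatter). The first step is still only a floor, and its true size stays unknown: the limit of > 25000 nM in this assay, at which 1 of the 4 values shown sits.

The compounds shown leave open how an amine or a carboxylic acid on this carbon would read, and whether a 3-methylphenyl or 4-methylphenyl ring would match the 2-methylphenyl ring. They also leave open whether a longer chain on the shared core would shift any of these numbers.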